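Amide nitrogen substituent variation, compound 3 to compound 4

This account rests on a few compounds, and the source may have more. Where it says the series, first, only, none or still open, it means among the compounds named here.

Of the compounds shown here, three sharing one core have been measured in a functional assay on B16-F10 cells (Mus musculus) for inhibition, read by MTT assay, with a stated time of 48 h; a higher number here means a weaker inhibitor, a lower number a stronger inhibitor. Compound 1 `CCNC(=O)/C=C/c1c(/C=C/c2ccc(OC)cc2)cc(OC)cc1OC` gives 6990 nM, compound 2 `COc1ccc(/C=C/c2cc(OC)cc(OC)c2/C=C/C(=O)N2CCCCC2C)cc1` gives 7660 nM, and compound 3 `COc1ccc(/C=C/c2cc(OC)cc(OC)c2/C=C/C(=O)Nc2cc(OC)c(OC)c(OC)c2)cc1` gives 8150 nM. Compound 3 holds the highest of the three numbers, but compound 2 and compound 1 both lie within the scatter of it. The two measured steps each alter the group on the amide-type nitrogen: a 1.1-fold higher number from compound 1 to compound 2 (0.04 log units; within the scatter) and a 1.2-fold higher number from compound 1 to compound 3 (0.07 log units; within the scatter). Compound 4 `CCCCCCNC(=O)/C=C/c1c(/C=C/c2ccc(OC)cc2)cc(OC)cc1OC` arises from compound 3 by hexyl in place of 3,4,5-trimethoxyphenyl on an amide-type nitrogen, again a change on the amide-type nitrogen. A step of similar size, none beyond the scatter, is expected in this assay, a 1.1-fold lower number from compound 3 to compound 4 (0.04 log units; within the scatter). Compound 4 is estimated at 7500 nM, within 3500 nM to 16000 nM.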

Compound 4, half-maximal inhibitory concentration: 7180 nM
Estimate against measurement, compound 4: 1.0-fold (0.02 log units) above, within the range that was stated.
By their numbers in this assay, from the lowest: compounds 1, 4, 2 and 3 (each within the scatter of the next).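

In this assay, hexyl in place of 3,4,5-trimethoxyphenyl on the amide-type nitrogen removes the aromatic ring from this position, yet the step stays within the scatter (a 1.1-fold lower number from compound 3 to compound 4 (0.06 log units; within the scatter)). Exchanging 2-methylpiperidin-1-yl for hexylamino (a 1.1-fold lower number from compound 2 to compound 4 (0.03 log units; within the scatter)) and extending the chain with butyl in place of hydrogen (a 1.0-fold higher number from compound 1 to compound 4 (0.01 log units; within the scatter)) also stay within it, so ethyl, hexyl, the trimethoxyphenyl group and the methylpiperidine amide are not told apart here. No evidence bears on this result. Still open, on these data alone, is whether a chain longer than hexyl, or a terminal amine or carboxylic acid on the chain, would give a step beyond the scatter.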